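A few compounds are considered here, and "the series" means these few. Any claim that something is new, unique, unknown or untested is made for them only; others in the source may bear on it.

Among the measured compounds shown here, compound 2 `N#CCOc1ccc2c(c1)CCc1c-2c2c(c3c4ccccc4n(CCO)c13)CNC2=O` gives 30% in an assay on isolated protein for inhibition of mitogen-activated protein kinase kinase kinase 9 (Homo sapiens), tested at 1 uM; on this read-out higher numbers stand for more inhibition at the one concentration tested (going by the name of the read-out) and lower numbers for less inhibition; its only measured neighbour, compound 1 `O=C1NCc2c1c1c(c3c2c2ccccc2n3CCO)CCc2cc(OC3CCCCC3)ccc2-1`, gives 35%, and the two sit within the scatter of each other. For the measured compounds named here, the single step between them, a number 5 percentage points lower from compound 1 to compound 2 (within the scatter), is the only comparison that bears on the next change. Compound 3 `O=C1NCc2c1c1c(c3c2c2ccccc2n3CCO)CCc2cc(OCC3CC3)ccc2-1` differs from compound 2 by cyclopropyl in place of cyano on a saturated chain carbon bound to an oxygen on an aromatic ring. Because a number 5 percentage points lower from compound 1 to compound 2 (within the scatter) stayed within the scatter for a larger change on the same oxygen, no step beyond the scatter is expected here either. For compound 3 the expected value is 33%, range 20% to 48%, an estimated step of a number 3 percentage points higher from compound 2 to compound 3 (within the scatter).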

Compound 3, a percentage reported as inhibition, at one concentration (the size of the read-out at that concentration, not a potency): 30%
Estimate against measurement, compound 3: 3 percentage points above; measured number inside the range.
By their numbers in this assay, from the lowest: compounds 2, 3 and 1 (each within the scatter of the next).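

Cyclopropyl in place of cyano on a saturated chain carbon bound to an oxygen on an aromatic ring gives no change at the digits printed from compound 2 to compound 3 (within the scatter) in this assay and cyclopropylmethyl in place of cyclohexyl gives a number 5 percentage points lower from compound 1 to compound 3 (within the scatter) on the same oxygen. Cyclohexyl, cyanomethyl and cyclopropylmethyl on this oxygen therefore all read within the scatter of one another, and the nitrile can go without the number leaving the scatter. No supporting data on hand account for this flat reading.

Going by these compounds, whether an amine, a carboxylic acid or a longer chain on this oxygen would move the number beyond the scatter stays open. Also open, on these data alone, is how a free hydroxyl at this place would read.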